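Compound 4 and the Aryl Ketone Swap

This account rests on a few compounds, and the source may have more. Where it says the series, first, only, none or still open, it means among the compounds named here.

Measured in a functional assay on A549 cells (Homo sapiens) for antiproliferative activity, read by XTT assay, with a stated time of 72 h; a lower number here means a stronger inhibitor, a higher number a weaker inhibitor:
- compound 1 `COc1ccc(-c2cc3ccccc3nc2C=O)cc1`: > 10000 nM (a limit)
- compound 2 `COc1ccc(-c2cc3ccccc3nc2/C=C/C(=O)c2ccc(F)cc2)cc1`: 8320 nM
- compound 3 `COc1ccc(-c2cc3ccccc3nc2/C=C/C(=O)c2ccc(OC)c(OC)c2)cc1`: 8860 nM

Compound 1 gives > 10000 nM, which is a limit and not a number. Compound 3 gives 8860 nM and compound 2 gives 8320 nM, so these two stand within the scatter of each other.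

The next compound, compound 4 `COc1ccc(-c2cc3ccccc3nc2/C=C/C(=O)c2ccc(Br)s2)cc1`, differs from compound 3 as follows: 5-bromothiophen-2-yl in place of 3,4-dimethoxyphenyl on a carbonyl carbon. Among the compounds with values here, only one measured step changes the same place on the carbonyl carbon, namely a 1.1-fold higher number from compound 2 to compound 3 (0.03 log units; within the scatter). That exchange of 3,4-dimethoxyphenyl for 4-fluorophenyl left the number within the scatter. It is a single step, however, and no five-membered aromatic ring has yet been measured at this place, so the expectation is loose. On this basis, no step beyond the scatter is expected in this assay. The upper side of the range meets (the limit of > 10000 nM in this assay, at which 1 of the 3 values shown sits), so compound 4 could also return only a limit. The estimated step is a 1.2-fold lower number from compound 3 to compound 4 (0.07 log units; within the scatter). Compound 4 is expected at 7500 nM, with an estimated range from 3000 nM to 10000 nM.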

Compound 4, half-maximal inhibitory concentration: 6250 nM
Estimate against measurement, compound 4: 1.2-fold (0.08 log units) above, within the range that was stated.
By their numbers in this assay, from the lowest: compounds 4, 2 and 3 (each within the scatter of the next). At a limit, above all of these: compound 1.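

In this assay, within the data shown here, 5-bromothiophen-2-yl is the first five-membered aromatic ring at this place on the carbonyl carbon, and it leaves the number within the scatter of both six-membered aromatic groups: a 1.4-fold lower number from compound 3 to compound 4 (0.15 log units; within the scatter), and a 1.3-fold lower number from compound 2 to compound 4 (0.12 log units; within the scatter). Across compounds 2, 3 and 4, then, the aromatic group on the carbonyl carbon changed in ring size and in its hetero atoms and substituents, yet no step beyond the scatter appeared, which extends the single earlier reading to a second ring type. Among the values shown, the only limit still belongs to compound 1, and compound 4 did not join it: the limit of > 10000 nM in this assay, at which 1 of the 4 values shown sits.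

What the compounds shown leave open is whether a group of another kind on this carbonyl carbon, such as an amine, a carboxylic acid or a longer alkyl chain, would give a step beyond the scatter. Also open, going by these compounds, is what a thiophen-2-yl ring without its bromine would give, so the ring and the bromine cannot be read apart.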